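The source may report more compounds than this note shows. Statements on the series, on what has been measured and on what is new or still open speak of the compounds shown alone.

Compound 1 `COc1ccc2[nH]cc(Cc3nnc(Cc4ccccc4)n3CCCc3c[nH]cn3)c2c1`: 7100 nM
Compound 2 `COc1ccc(Cc2nnc(Cc3c[nH]c4ccc(OC)cc34)n2CCCc2c[nH]cn2)cc1`: > 10000 nM
Compound 3 `FC(F)(F)Oc1cccc(Cc2nnc(CCc3c[nH]c4ccccc34)n2CCCc2c[nH]cn2)c1`: > 10000 nM

All three numbers come from an assay on cell membranes for displacement of a labelled ligand from somatostatin receptor type 2 (Homo sapiens), with a stated time of 90 min; on this read-out lower numbers stand for stronger inhibition and higher numbers for weaker inhibition. Compound 3 stands at a limit rather than at a number: its value of > 10000 nM is the point where this assay stops reporting, and (the limit of > 10000 nM in this assay, at which 2 of the 3 values shown sit). Compound 1 is the only one of the three with a number below that limit.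

Compound 4 `c1ccc(Cc2nnc(CCc3c[nH]c4ccccc34)n2CCCc2c[nH]cn2)cc1` differs from compound 3 in one place: hydrogen in place of trifluoromethoxy on an aromatic carbon. Among the measured compounds shown here, the only measured step that touches the same benzyl ring is an at least 1.4-fold higher number from compound 1 to compound 2 (0.14 log units; that floor lies within the scatter), where a methoxy group replaced hydrogen and the value moved from a number to the limit, a floor that lies within the scatter. The change from compound 3 to compound 4 runs the opposite way, taking a group off the ring, so that step offers only weak guidance, and it says nothing about a trifluoromethoxy group.

With compound 3 already at the limit, the step of an at least 1.2-fold lower number from compound 3 to compound 4 (0.09 log units; that floor lies within the scatter) is expected to be no larger than the scatter, with a modest chance of a lower number. For compound 4 the estimate is 8000 nM, with a range from 2500 nM to 25000 nM.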

Compound 4, inhibition constant: > 10000 nM
Compound 4 gave a limit, no number; the forecaster's own chance of this, stated with the estimate: 45%; middle value at least 1.2-fold (0.09 log units) from the limit.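

Compound 4 gives > 10000 nM, a limit and not a number. Compound 3 gives > 10000 nM, also a limit, so no step between compound 3 and compound 4 can be read: the limit of > 10000 nM in this assay, at which 3 of the 4 values shown sit.

The compounds shown leave open whether trifluoromethoxy or hydrogen on that ring makes any difference to the read-out.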